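The compounds below may be only part of what the source reports. "The series", "measured", "known", "first", "only" and "open" are said of these compounds alone.

Compound 2 `NCc1ccc(S(=O)(=O)[N-][N+](=O)[O-])cc1` gives the lowest of the two numbers recorded so far in an ADME assay on isolated protein for inhibition of carbonic anhydrase 4 (Homo sapiens), read by stopped-flow, with a stated time of 15 min (a lower number here means a stronger inhibitor, a higher number a weaker inhibitor), at 3100 nM. Its nearest neighbour is compound 1 `Nc1ccc(S(=O)(=O)[N-][N+](=O)[O-])cc1`, which in this assay gives 23600 nM; the pair differs only in that compound 2 carries aminomethyl where compound 1 carries amino on an aromatic carbon, and this single change produced a 7.6-fold lower number from compound 1 to compound 2 (0.88 log units; beyond the scatter).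

Compound 3 `CN(C)c1ccc(S(=O)(=O)[N-][N+](=O)[O-])cc1` has not yet been measured. It differs from compound 2 as follows: dimethylamino in place of aminomethyl on an aromatic carbon. So the aminomethyl whose arrival was accompanied by a 7.6-fold lower number from compound 1 to compound 2 (0.88 log units; beyond the scatter) is taken away again, and a dimethylamino is placed on the same aromatic carbon instead. Among the measured compounds shown here, that step is the only measured one that bears on compound 3, and it is the sole guide here, since no compound with dimethylamino has been measured in this assay.

For the measured compounds named here, because the one known step, a 7.6-fold lower number from compound 1 to compound 2 (0.88 log units; beyond the scatter), lowered the number when aminomethyl replaced amino, its removal is expected to move the number back up, with compound 3 estimated at 15000 nM, within a range from 5000 nM to 50000 nM. The step that this estimate implies is expected to be a 4.8-fold higher number from compound 2 to compound 3 (0.68 log units; beyond the scatter).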

Compound 3, inhibition constant: 11000 nM
Estimate against measurement, compound 3: 1.4-fold (0.13 log units) above; the measured number falls inside the stated range.
By their numbers in this assay, from the lowest: compound 2; then compound 3; then compound 1.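

In this assay, the aromatic carbon para to a group of 7 heavy atoms now carries three different groups, and replacing aminomethyl with dimethylamino gives a 3.5-fold higher number from compound 2 to compound 3 (0.55 log units; beyond the scatter) on the shared core. Aminomethyl therefore still gives the lowest number of the three, so the earlier gain did not simply appear with any group larger than amino. Dimethylamino in place of amino still gives a 2.1-fold lower number from compound 1 to compound 3 (0.33 log units; beyond the scatter), which places compound 3 between the other two and shows that a lower number than that of compound 1 is not confined to aminomethyl, while no measurement on these compounds explains the order.

These compounds change the size of the group and its count of hydrogen-bond donors together, with aminomethyl having 1 hydrogen-bond donor and dimethylamino 0 hydrogen-bond donors, so the two cannot be told apart here. A dimethylaminomethyl group would keep the carbon link of aminomethyl and the two methyl groups of dimethylamino, while a longer aminoethyl chain or a carboxylic acid would show how far the trend extends, and none of these can be judged from the present numbers.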